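A Hydroxyl on the Ethyl Chain of Compound 3

This account rests on a few compounds, and the source may have more. Where it says the series, first, only, none or still open, it means among the compounds named here.

Measured so far:
- Compound 1, `O=C(O)c1cc(-c2ccc(-c3ccc(Cl)cc3Cl)cc2)n(-c2ccccn2)n1`. In an assay on isolated protein for inhibition of methionine--tRNA ligase, cytoplasmic (Homo sapiens) (on this read-out higher numbers stand for weaker inhibition and lower numbers for stronger inhibition), compound 1 gives > 100000 nM, which is a limit of the assay and not a number.
- Compound 2, `COc1ccc(-n2nc(C(=O)O)cc2-c2ccc(-c3ccc(Cl)cc3Cl)cc2)cc1`. In this assay compound 2 gives > 100000 nM, again a limit of the assay.
- Compound 3, `CCn1nc(C(=O)O)cc1-c1ccc(-c2ccc(Cl)cc2Cl)cc1`. In this assay compound 3 gives 46400 nM.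

Among the measured compounds shown here, compound 3 therefore stands alone: it is the only compound of the three with an actual number, while the other two sit at the limit of > 100000 nM in this assay, at which 2 of the 3 values shown sit. The two readable steps both end at compound 3. From compound 1 to compound 3, an at least 2.1-fold lower number from compound 1 to compound 3 (0.33 log units; beyond the scatter); from compound 2 to compound 3, an at least 2.1-fold lower number from compound 2 to compound 3 (0.33 log units; beyond the scatter). Both replace a ring on the aromatic nitrogen with a short ethyl chain, and both improve inhibition at least modestly. The step from compound 1 to compound 2 is a step that the two limits leave unreadable from compound 1 to compound 2.

Compound 4, `O=C(O)c1cc(-c2ccc(-c3ccc(Cl)cc3Cl)cc2)n(CCO)n1`, keeps the ethyl chain and alters only its end: hydroxy in place of hydrogen on a saturated chain carbon, two bonds along the chain from an aromatic nitrogen. For the measured compounds named here, no measured step touches a hydroxy group, so the two steps into compound 3 give no direct guide; they only show that the chain itself is tolerated. With nothing pointing either way, compound 4 is expected to sit close to compound 3, with a step of a 1.0-fold lower number from compound 3 to compound 4 (0.01 log units; within the scatter) that stays within the scatter. The estimate for compound 4 in this assay is 45000 nM, between 15000 nM and 130000 nM.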

Compound 4, half-maximal inhibitory concentration: > 100000 nM
Compound 4 gave a limit, no number (the forecaster's own chance of this, stated with the estimate: 30%); middle value at least 2.2-fold (0.34 log units) away from the limit.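

Adding one oxygen atom, as a hydroxy group on a saturated chain carbon, produces an at least 2.1-fold higher number from compound 3 to compound 4 (0.33 log units; beyond the scatter) in this assay. The earlier steps shown here showed only that an ethyl chain on the aromatic nitrogen gives a readable number, whereas this step shows that a change of a single heavy atom at the end of that chain is enough to lose it. The value of compound 4 is a limit of the assay and not a number, so the full size of the loss stays unknown, the steps to compound 4 from compounds 1 and 2 cannot be read, and compound 3 remains the only compound with a number: the limit of > 100000 nM in this assay, at which 3 of the 4 values shown sit.

On these data alone, it remains open whether this loss is specific to the hydroxy group or would also follow from other groups in that place, such as a methoxy group, an amine or a fluorine. The compounds shown also leave open whether a plain methyl or a longer propyl chain on the aromatic nitrogen would give a lower number than compound 3.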